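This account rests on a few compounds, and the source may have more. Where it says the series, first, only, none or still open, it means among the compounds named here.

Measured so far:
Compound 1, `Cc1ccc(N2CCn3c2n[nH]c(=O)c3=O)cc1`: 20%
Compound 2, `N=c1c(=O)[nH]nc2n1CCN2c1ccc(Cl)cc1`: 25%

Of the compounds shown here, two of the shared core have been tested in a functional assay on A549 cells (Homo sapiens) for antiproliferative activity, with a stated time of 72 h, tested at 10 ug/mL; a higher number here means a stronger effect of the compound at the concentration tested, a lower number a weaker effect. In this assay compound 1 gives 20%, and compound 2 gives 25%. The two numbers are only a few points apart, a gap that falls inside the usual scatter of repeated measurements, so neither compound can be said to act more strongly than the other; compound 1 simply stands as one of two readings that cannot be told apart.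

Compound 3, `COc1ccc(N2CCn3c2n[nH]c(=O)c3=O)cc1`, has not yet been measured. It differs from compound 1 in a single place: methoxy in place of methyl on an aromatic carbon. Among the measured compounds shown here, no measured pair in this set shows what such an exchange does in this assay, so there is no directly comparable step to lean on.

Given the small size of the change and the narrow range of the two numbers known so far, the step from compound 1 to compound 3 is expected to be small, a number 4 percentage points higher from compound 1 to compound 3 (within the scatter), not beyond the scatter in either direction. Compound 3 is therefore estimated to give about 24% in this assay, with a likely range from 10% to 40%.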

Compound 3, a percentage reported as inhibition, at one concentration (the size of the read-out at that concentration, not a potency): 0%
Compound 3: the middle estimate sits 24 percentage points above what was measured, and the stated range ends above it.
By their numbers in this assay, from the lowest: compound 3; then compounds 1 and 2 (each within the scatter of the next).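

In this assay, among the compounds shown here, methoxy in place of methyl on an aromatic carbon, para to a large group, gives a number 20 percentage points lower from compound 1 to compound 3 (beyond the scatter), the first step in this set that can be read as a real difference. Compound 3 gives 0%, so at the concentration tested this read-out shows no effect for it, whereas compound 1 retains the modest reading of 20%. For the compounds shown here, this position on the six-membered aromatic ring is therefore not indifferent to what it carries, even with an exchange this small, although the single pair shows only that the reading changes and nothing available explains why.

The compounds shown leave open how far this sensitivity extends: whether a hydroxyl group, an amine, a carboxylic acid or a longer chain such as ethoxy at the same place would keep the reading of compound 1 or lose it as compound 3 does. They also leave open whether the same exchange of methyl for methoxy would have a comparable effect on a different version of the shared core.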